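The source may hold more compounds than are shown below. What is called first, only, known or untested is meant among the compounds shown, and "the series" means these compounds.

Two compounds share one core and differ only in a single aromatic substituent. Compound 1 `COc1cc(-c2nn(-c3ccc(NC(=O)Nc4ccc(Cl)c(Cl)c4)cc3)cc2-c2ccncc2)ccc1Cl` gives 3170 nM in a functional assay on UACC-257 cells (Homo sapiens) for antiproliferative activity, read by sulforhodamine B assay, with a stated time of 48 h; a lower number here means a stronger inhibitor, a higher number a weaker inhibitor; compound 2 `COc1cc(-c2nn(-c3ccc(NC(=O)Nc4ccc(Cl)c(C(F)(F)F)c4)cc3)cc2-c2ccncc2)ccc1Cl` gives 1640 nM in the same assay. For the measured compounds named here, the only step so far, a 1.9-fold lower number from compound 1 to compound 2 (0.29 log units; within the scatter), is small. Compound 2 therefore stands with the lower of the two numbers, yet its gap to compound 1 is within the scatter, so no order between them can be claimed.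

Compound 3 `COc1cc(-c2nn(-c3ccc(NC(=O)c4ccc(Cl)c(Cl)c4)cc3)cc2-c2ccncc2)ccc1Cl` is the next compound to be measured in this assay. Its change from compound 2 is 3,4-dichlorophenyl in place of (4-chloro-3-(trifluoromethyl)phenyl)amino on a carbonyl carbon. This change has two parts: the trifluoromethyl of compound 2 returns to chloro, as in compound 1, and one nitrogen leaves the linker. Only the first part is covered by a measured step, and that step, a 1.9-fold lower number from compound 1 to compound 2 (0.29 log units; within the scatter), was within the scatter. For the loss of the nitrogen nothing comparable has been measured, so the expectation rests on compound 1 and compound 2 alone and carries a wide range. Compound 3 is estimated at 3500 nM, between 1200 nM and 10000 nM, which means an expected step of a 2.1-fold higher number from compound 2 to compound 3 (0.33 log units; beyond the scatter).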

Compound 3, half-maximal inhibitory concentration: > 100000 nM
Compound 3 ended at the assay's limit (the forecaster's own chance of this, stated with the estimate: 10%); middle value at least 28-fold (1.45 log units) away from the limit.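

Removing only the amino nitrogen from the linker, while the 3,4-dichlorophenyl group stays in place on the carbonyl carbon, gives an at least 31-fold higher number from compound 1 to compound 3 (1.49 log units; beyond the scatter), so in this assay this single atom and the hydrogen it carries make a very large difference within this pair. The wider change, which also puts chloro back in place of trifluoromethyl, gives an at least 60-fold higher number from compound 2 to compound 3 (1.78 log units; beyond the scatter), whereas the swap between those two substituents alone gave only a 1.9-fold lower number from compound 1 to compound 2 (0.29 log units; within the scatter), so the linker change, not the ring substituent, accounts for nearly all of the loss among these compounds. The result for compound 3 is a limit and not a number, so its true size remains unknown, and both large steps are minimum sizes: the limit of > 100000 nM in this assay, at which 1 of the 3 values shown sits.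

The compounds shown cannot separate the role of the nitrogen from that of its hydrogen; a methyl group on that nitrogen, or an oxygen or a methylene group in its place, would help to tell these apart. As far as these compounds go, it also remains open whether the same loss would appear with the 4-chloro-3-(trifluoromethyl)phenyl group attached directly to the carbonyl carbon.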